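An Expected Toxicity Value for Compound 3

The compounds below may be only part of what the source reports. "The series", "measured", "known", "first", "only" and "open" are said of these compounds alone.

Compound 1 `COc1ccc(/C=C/C(=O)c2ccccc2NC(=O)NS(=O)(=O)c2ccc(C)cc2)c(OC)c1` was tested in an ADME assay on the whole organism for cytotoxicity, with Artemia salina as the target, with a stated time of 24 h (on this read-out lower numbers stand for an effect already at smaller amounts and higher numbers for an effect only at larger amounts of compound), where compound 1 gives 16 ug/mL. For the measured compounds named here, of the two numbers measured so far, that of compound 1 is the highest, and its nearest neighbour is compound 2 `Cc1ccc(S(=O)(=O)NC(=O)Nc2ccccc2C(=O)/C=C/c2ccccc2Cl)cc1`, which in this assay gives 12.8 ug/mL. Going by the values given here, the single measured step, a 1.3-fold lower number from compound 1 to compound 2 (0.10 log units; within the scatter), comes from putting 2-chlorophenyl in place of 2,4-dimethoxyphenyl on a double-bonded chain carbon bound to a double-bonded chain carbon, and it stays within the scatter.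

Compound 3 `Cc1ccc(S(=O)(=O)NC(=O)Nc2ccccc2C(=O)/C=C/c2ccc[nH]2)cc1` has not yet been measured. It differs from compound 1 at that same place: 1H-pyrrol-2-yl in place of 2,4-dimethoxyphenyl on a double-bonded chain carbon bound to a double-bonded chain carbon. Among the compounds with values here, no measured step covers a 1H-pyrrol-2-yl entering at this place. Within the data shown here, the only step that bears on it, a 1.3-fold lower number from compound 1 to compound 2 (0.10 log units; within the scatter), shows that exchanging the 2,4-dimethoxyphenyl for another ring at this place left this assay essentially unchanged. A step not beyond the scatter is therefore expected. For compound 3 the expected step is a 1.1-fold lower number from compound 1 to compound 3 (0.03 log units; within the scatter). In this assay compound 3 is estimated at 15 ug/mL, with a range from 7 ug/mL to 35 ug/mL.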

Compound 3, concentration for half-maximal effect: 32.1 ug/mL
For compound 3 the middle estimate is 2.1-fold (0.33 log units) below the measured one; the measured number falls inside the stated range.
By their numbers in this assay, from the lowest: compounds 2, 1 and 3 (each within the scatter of the next, the first and the last beyond it).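

In this assay the step to the 1H-pyrrol-2-yl group, a 2.0-fold higher number from compound 1 to compound 3 (0.30 log units; within the scatter), still cannot be told apart from no change, even though this five-membered ring has fewer heavy atoms than the 2,4-dimethoxyphenyl it replaces and brings a hydrogen-bond donor. For the compounds shown here, the other new step, a 2.5-fold higher number from compound 2 to compound 3 (0.40 log units; beyond the scatter), is modest but beyond the scatter, and it gives the first sign that exchanging one ring for another at this place can shift the number measurably; the only earlier step could not show this. No measurement available here accounts for that shift.

From the compounds shown here alone, it remains open which feature of the 1H-pyrrol-2-yl group goes with this gap, and rings such as furan-2-yl or 1-methylpyrrol-2-yl would help to separate the effect of ring size from that of the ring's hydrogen on nitrogen. Every compound shown carries an aromatic ring at this place, so it also remains open how an amine or a longer carbon chain there would read in this assay.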